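This account rests on a few compounds, and the source may have more. Where it says the series, first, only, none or still open, it means among the compounds named here.

Of the compounds shown here, three have been measured so far in an assay on isolated protein for activation of Nicotinamide phosphoribosyltransferase (Homo sapiens); a higher number here means that more compound is needed for the effect, a lower number that less compound is needed. Compound 1 `O=C(NCc1ccncc1)Nc1ccc(S(=O)(=O)N2CC3CCC(C2)O3)cc1` gives 279 nM in this assay, the second highest number among the three. Compound 3 `O=C(NCc1cnco1)Nc1ccc(S(=O)(=O)c2ccccc2)cc1` gives 77 nM in this assay, a lower number than compound 1 by a gap beyond the scatter. Compound 2 `CCOC(=O)c1ccc(NC(=O)OCc2ccncc2)cc1` gives 10800 nM in this assay, a far higher number than compound 1, also beyond the scatter. Compound 4 `CN(C)S(=O)(=O)c1ccc(NC(=O)NCc2ccncc2)cc1` has not yet been measured. It differs from compound 1 at a single place: a group of 3 heavy atoms (2 carbon, 1 nitrogen; no ring) in place of a group of 8 heavy atoms (6 carbon, 1 nitrogen, 1 oxygen; one five-membered non-aromatic ring with 1 hetero atom, one six-membered non-aromatic ring with 2 hetero atoms), on a sulfonyl sulfur. The rest of the shared core is unchanged. Among the measured compounds shown here, no pair of measured compounds shows what such a trimming of the group on the sulfonyl sulfur does to the number, so the size of the step is a judgement, not a reading from the data. The expectation is a modest rise in this assay, about a 1.5-fold higher number from compound 1 to compound 4 (0.18 log units; within the scatter), close to the edge of the usual scatter. Compound 4 is estimated at 420 nM, with a range from 150 nM to 1200 nM.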

Compound 4, half-maximal effective concentration: 3110 nM
Compound 4: middle estimate off by 7.4-fold (0.87 log units), on the low side; the measured number lies above the stated range.
By their numbers in this assay, from the lowest: compound 3; then compound 1; then compound 4; then compound 2.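

In this assay, the group on the sulfonyl sulfur turns out to matter a great deal: replacing the ring-bearing group of 8 heavy atoms with dimethylamino gives an 11-fold higher number from compound 1 to compound 4 (1.05 log units; beyond the scatter) and leaves the rest of the shared core unchanged. This single change is therefore enough to produce a large step, and here the ring-bearing group goes with less compound being needed for the effect. No measurement shown explains why the number moves this far.

Among the compounds shown here, with only this one pair, it remains open whether the step follows the number of heavy atoms, the rings or the ring oxygen. A diethylamino, piperidine or morpholine group on the sulfonyl sulfur would help to separate these three features.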